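The source may report more compounds than this note shows. Statements on the series, on what has been measured and on what is new or still open speak of the compounds shown alone.

Measured compounds:
compound 1, `COc1ccc(-c2cc(/C=C/C(=O)c3ccc(N)cc3)[nH]n2)cc1`, 95%
compound 2, `COc1cc(-c2cc(/C=C/C(=O)c3ccc(N)cc3)[nH]n2)cc(OC)c1OC`, 95%

The account follows the step from compound 2 to compound 3. Compound 2 carries three methoxy groups on its outer six-membered ring and was tested in a functional assay on NCI-H322M cells (Homo sapiens) for cytotoxicity, read by sulforhodamine B assay, with a stated time of 48 h, tested at 0.01 uM (a higher number here means a weaker effect of the compound at the concentration tested, a lower number a stronger effect), where compound 2 gives 95%. Its nearest neighbour among the measured compounds is compound 1, which carries a single methoxy group on that ring; in this assay compound 1 gives 95%. The two values are level at the digits shown and their gap lies within the scatter of repeated measurements, so no order between compound 2 and compound 1 can be stated.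

Compound 3, `COc1ccc(-c2cc(/C=C/C(=O)c3ccc(N)cc3)[nH]n2)cc1OC`, has not yet been measured. It differs from compound 2 in one place: hydrogen in place of methoxy on an aromatic carbon.

Among the compounds with values here, no measured pair in this set shows what such a change does. With compound 1 and compound 2 sitting at the same value, the step from compound 2 to compound 3 is expected to be no change at the digits printed from compound 2 to compound 3 (within the scatter), that is, none beyond the scatter. Compound 3 is therefore estimated at 95%, with a range from 85% to 102%.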

Compound 3, a percentage reported as activity, at one concentration (the size of the read-out at that concentration, not a potency): 96%
The estimate for compound 3 lay 1 percentage points below the measured number; the range from low to high includes it.
By their numbers in this assay, from the lowest: compounds 1, 2 and 3 (each within the scatter of the next).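

In this assay, hydrogen in place of methoxy on this aromatic carbon, ortho to a methoxy group and meta to a large group, gives a number 1 percentage points higher from compound 2 to compound 3 (within the scatter), and methoxy in place of hydrogen on an aromatic carbon gives a number 1 percentage points higher from compound 1 to compound 3 (within the scatter). Within the data shown here, these are the first pairs in the set that differ in one place, so the methoxy groups on the outer ring can now be read one at a time rather than only by comparing the single-methoxy and three-methoxy compounds, and neither step lies beyond the scatter at the one concentration tested. Nothing measured here bears on why these values sit together.

From the compounds shown here alone, the three compounds carry only methoxy or hydrogen at these places on the ring, so it remains open whether a hydroxy group, an amine, a chlorine atom or a longer alkoxy chain would give a read-out that stands apart from theirs. As the read-out is the size of the effect at a single concentration, it also leaves open whether these compounds would separate at other concentrations.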